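Cyclohexyl in place of cyclohexylmethyl on the ring nitrogen

A few compounds are considered here, and "the series" means these few. Any claim that something is new, unique, unknown or untested is made for them only; others in the source may bear on it.

Compound 2 `CCOC(=O)c1cnc(NCC2CCCCC2)n2nc(-c3ccco3)nc12` is the reference point of the series. For the measured compounds named here, in an assay on CHO cells for displacement of a labelled ligand from adenosine receptor A1 (Homo sapiens) (a lower number here means a stronger inhibitor, a higher number a weaker inhibitor), compound 2 gives 432 nM, the lowest of the two numbers so far, with compound 3 nearest. Compound 3 `CCOC(=O)c1cnc(NCc2ccc(F)cc2)n2nc(-c3ccco3)nc12` gives 932 nM in this assay. Going by the values given here, the step of a 2.2-fold higher number from compound 2 to compound 3 (0.33 log units; beyond the scatter) is the only measured change at this nitrogen, and it exchanges one ring for another while keeping the saturated carbon that joins it to the nitrogen. Compound 1 `O=C(Nc1ncc(C(=O)O)c2nc(-c3ccco3)nn12)NC1CCCCC1` differs from compound 2 in more than one place. In this assay compound 1 gives > 100000 nM, which is a limit and not a number (the limit of > 100000 nM in this assay, at which 1 of the 3 values shown sits).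

Compound 4 `CCOC(=O)c1cnc(NC2CCCCC2)n2nc(-c3ccco3)nc12` is not yet measured. The change from compound 2 is cyclohexyl in place of cyclohexylmethyl on a nitrogen on an aromatic ring; the ring itself is kept, the carbon that joined it to the nitrogen is gone. Among the compounds with values here, no measured step removes this carbon, so the step from compound 2 to compound 3 bears only loosely, having been of modest size. The expectation for compound 4 is therefore a modest step, more likely towards a higher number than a lower one, and possibly none beyond the scatter. Compound 4 is estimated at 800 nM in this assay, in a range of 250 nM to 2500 nM, meaning an expected step of a 1.9-fold higher number from compound 2 to compound 4 (0.27 log units; within the scatter).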

Compound 4, inhibition constant: 141 nM
The estimate for compound 4 lay 5.7-fold (0.75 log units) above the measured number, outside the stated range (below it).
By their numbers in this assay, from the lowest: compound 4; then compound 2; then compound 3. At a limit, above all of these: compound 1.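

In this assay, for the compounds shown here, removing the carbon that joined the cyclohexyl ring to the nitrogen gives a 3.1-fold lower number from compound 2 to compound 4 (0.49 log units; beyond the scatter), so at this nitrogen the shorter cyclohexylamino group is the better of the two saturated options, and the only measured step so far had moved the other way. Set against the 4-fluorobenzyl group, cyclohexyl gives a 6.6-fold lower number from compound 3 to compound 4 (0.82 log units; beyond the scatter), which places compound 4 lowest of the three compounds with true numbers, its steps to both being beyond the scatter. Nothing in the data shown accounts for either step, and the only supporting line concerns a limit that has no bearing on this change.

Going by these compounds alone, whether the trend continues with a smaller ring such as cyclopentyl, with phenyl set directly on the nitrogen, or with a longer chain such as 2-cyclohexylethyl remains open, as the pair of compound 2 and compound 4 covers one ring with only two link lengths. Going by these compounds, the role of the ethyl ester is also open, as compound 1 differs from compound 2 in more than one place and its value is only a limit.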